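The source may report more compounds than this note shows. Statements on the series, on what has been measured and on what is new or still open speak of the compounds shown alone.

In a physicochemical assay for solubility, read by HPLC, in phosphate buffer, with a stated time of 24 h, at pH 7.4, tested at 100 uM (a lower number here means a less soluble compound, a higher number a more soluble compound), compound 1 `C[C@H](Nc1c(NCCCCCC(=O)NO)c(=O)c1=O)c1ccccc1` gives 73000000 nM and compound 2 `Cc1cccc(Nc2c(NCCCCCC(=O)NO)c(=O)c2=O)c1` gives 79000000 nM. These two sit within the scatter: a 1.1-fold higher number from compound 1 to compound 2 (0.03 log units; within the scatter). Compound 3 `Cc1ccc(Nc2c(NCCCCCC(=O)NO)c(=O)c2=O)cc1` is the lowest of the three at 8100000 nM. That standing rests on a 9.0-fold lower number from compound 1 to compound 3 (0.95 log units; beyond the scatter) and on a 9.8-fold lower number from compound 2 to compound 3 (0.99 log units; beyond the scatter). Compound 4 `O=C(CCCCCNc1c(Nc2ccc(C(F)(F)F)cc2)c(=O)c1=O)NO` comes from compound 3 by trifluoromethyl in place of methyl on an aromatic carbon. Within the data shown here, no measured step makes this exchange. The closest guide is a 9.8-fold lower number from compound 2 to compound 3 (0.99 log units; beyond the scatter), a change on the same ring, so a smaller step than that one is expected. In this assay the expected move is downward, an estimated 2.3-fold lower number from compound 3 to compound 4 (0.36 log units; beyond the scatter). Compound 4 is estimated at 3500000 nM, with a range of 1000000 nM to 12000000 nM.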

Compound 4, solubility: 4500000 nM
Compound 4: the middle estimate sits 1.3-fold (0.11 log units) below what was measured; low and high end bracket the measured number.
By their numbers in this assay, from the lowest: compounds 4 and 3 (each within the scatter of the next); then compounds 1 and 2 (each within the scatter of the next).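

In this assay trifluoromethyl in place of methyl on an aromatic carbon, para to a large group, gives a 1.8-fold lower number from compound 3 to compound 4 (0.26 log units; within the scatter) and so does not separate the two compounds. The earlier compounds shown here showed only a change in where the methyl sits on this ring, with a 9.8-fold lower number from compound 2 to compound 3 (0.99 log units; beyond the scatter) as a step beyond the scatter, whereas exchanging the group itself at this place stays within it. No measurement at hand explains either step.

Open, from the compounds shown here alone, is whether an amine or a carboxylic acid at this same place would also stay within the scatter of compound 3. Also open, going by these compounds, is whether trifluoromethyl in place of the methyl of compound 2 would stay within the scatter of compound 2.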